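The source may report more compounds than this note shows. Statements on the series, on what has been measured and on what is new or still open speak of the compounds shown alone.

The series shares one core, carried by compound 1 `Cc1cccc(-n2nncc2CN2C(=O)C3(C(C#N)=C(N)Oc4c3c3nc5ccccc5nc3c3ccccc43)c3ccccc32)c1`, compound 2 `COc1ccc(-n2nncc2CN2C(=O)C3(C(C#N)=C(N)Oc4c3c3nc5ccccc5nc3c3ccccc43)c3ccccc32)cc1` and compound 3 `N#CC1=C(N)Oc2c(N)cc3nc4ccccc4nc3c2C12C(=O)N(Cc1cnnn1-c1ccc([N+](=O)[O-])cc1)c1ccccc12`, while compound 4 `N#CC1=C(N)Oc2c(N)cc3nc4ccccc4nc3c2C12C(=O)N(Cc1cnnn1-c1c(Cl)cc(Cl)cc1Cl)c1ccccc12` has not yet been tested. In an ADME assay on L02 cells (Homo sapiens) for antiproliferative activity, read by MTT assay, with a stated time of 48 h (a higher number here means a weaker inhibitor, a lower number a stronger inhibitor), compound 1 gives > 50000 nM, a limit of the assay and not a number. In this assay compound 2 likewise gives only a limit, > 50000 nM. The step that the two limits leave unreadable from compound 1 to compound 2 therefore cannot be read. In this assay, within the data shown here, compound 3 gives > 50000 nM, again a limit rather than a number, so compound 3 stands where every value so far sits, at the limit of > 50000 nM in this assay, at which 3 of the 3 values shown sit. Compound 4 differs from compound 3 by 2,4,6-trichlorophenyl in place of 4-nitrophenyl on an aromatic nitrogen. Among the measured compounds shown here, no measured step bears directly on this change: the only step between measured compounds, a step that the two limits leave unreadable from compound 1 to compound 2, has no readable size, and all values shown rest at the limit (the limit of > 50000 nM in this assay, at which 3 of the 3 values shown sit). There is thus no basis for expecting a step beyond the scatter in this assay in either direction. The step that the limit leaves unreadable from compound 3 to compound 4 is estimated to be small. Compound 4 is estimated at 60000 nM in this assay, with a range from 25000 nM to 150000 nM, and most likely it will again be reported only as a limit.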

Compound 4, half-maximal inhibitory concentration: > 50000 nM
Compound 4: only a limit was reported (the forecaster's own chance of this, stated with the estimate: 75%); the middle value does not contradict the limit.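

In this assay, among these compounds, compound 4 gives > 50000 nM, a limit of the assay and not a number, so no step from compound 3 to compound 4 can be read. The compounds shown leave open how any group on the aromatic nitrogen would shift the value in this assay, because every value rests at one limit: the limit of > 50000 nM in this assay, at which 4 of the 4 values shown sit.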